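Sulfamoyl to methyl: tolerance in a cytotoxicity assay

The compounds below may be only part of what the source reports. "The series", "measured", "known", "first", "only" and "open" are said of these compounds alone.

In an ADME assay on MT4 cells (Homo sapiens) for cytotoxicity, read by MTT assay, with a stated time of 5 days (a lower number here means that less compound is tolerated, a higher number that more compound is tolerated), compound 1 (`COc1cc2nc(Nc3ccc(C#N)cc3)nc(Nc3c(C)cc(/C=C/C#N)cc3C)c2cc1OC`) gives 10200 nM. Compound 2 (`COc1ccc(NC(=O)CSc2nc(Nc3c(C)cc(/C=C/C#N)cc3C)c3cc(OC)c(OC)cc3n2)cc1`) is reported only as a limit, > 225000 nM. Compound 3 (`COc1cc2nc(SCC(=O)Nc3ccc(S(N)(=O)=O)cc3)nc(Nc3c(Cl)cc(/C=C/C#N)cc3Cl)c2cc1OC`) gives 116000 nM, the higher of the two actual numbers and beyond the scatter from compound 1. Compound 4 (`COc1cc2nc(SCC(=O)Nc3ccc(C)cc3)nc(Nc3c(Cl)cc(/C=C/C#N)cc3Cl)c2cc1OC`) differs from compound 3 in one place, with methyl in place of sulfamoyl on an aromatic carbon, para to a large group: methyl in place of sulfamoyl on an aromatic carbon. Going by the values given here, no measured pair shows this change alone, so the expectation stays close to compound 3 at 116000 nM. A small step toward a lower number is expected, a 1.7-fold lower number from compound 3 to compound 4 (0.22 log units; within the scatter). Compound 4 is estimated at 70000 nM, with an expected range of 17000 nM to 230000 nM.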

Compound 4, half-maximal cytotoxic concentration: 2540 nM
For compound 4 the middle estimate is 28-fold (1.44 log units) above the measured one, and the stated range ends above it.
By their numbers in this assay, from the lowest: compound 4; then compound 1; then compound 3. At a limit, above all of these: compound 2.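

In this assay, methyl in place of sulfamoyl gives a 46-fold lower number from compound 3 to compound 4 (1.66 log units; beyond the scatter), the first step shown that isolates a single change. Going by these compounds alone, this aromatic carbon, para to a large group, therefore matters strongly for tolerance, which the earlier compounds, differing from one another in more than one place, could not show. Nothing at hand bears on why the number moves. From the compounds shown here alone, it remains open whether losing sulfamoyl or gaining methyl drives the step. Hydrogen, an amine or a carboxylic acid at this place lies outside the compounds shown.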